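Replacing the anilino group with a methylpiperazine

A few compounds are considered here, and "the series" means these few. Any claim that something is new, unique, unknown or untested is made for them only; others in the source may bear on it.

Measured compounds:
compound 1 `Cc1ccc(Nc2nc(Cl)nc3c2ncn3Cc2ccc(C(=O)Nc3ccccc3N)cc2)cc1` gives 76.2%
compound 2 `Nc1ccccc1NC(=O)c1ccc(Cn2cnc3c(Nc4cccc(OC(F)(F)F)c4)nc(Cl)nc32)cc1` gives 1.88%
compound 3 `Nc1ccccc1NC(=O)c1ccc(Cn2cnc3c(Nc4cccc(Cl)c4)nc(Cl)nc32)cc1` gives 29.9%

All three share one core and differ only in the group on the nitrogen attached to it. In a functional assay on HepG2 cells (Homo sapiens) for antiproliferative activity, read by CCK-8 assay, with a stated time of 72 h, tested at 2 uM (on this read-out lower numbers stand for a weaker effect and higher numbers for a stronger effect at the one concentration tested), compound 1 gives 76.2%, compound 3 gives 29.9%, and compound 2 gives 1.88%. Compound 3 stands second of the three: a number 46.3 percentage points lower from compound 1 to compound 3 (beyond the scatter), while a number 28 percentage points higher from compound 2 to compound 3 (beyond the scatter).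

Compound 4 `CN1CCN(c2nc(Cl)nc3c2ncn3Cc2ccc(C(=O)Nc3ccccc3N)cc2)CC1` takes this series in a new direction. The change is 4-methylpiperazin-1-yl in place of (3-chlorophenyl)amino on an aromatic carbon. The three measured steps all bear on the same place and were large: a number 74.3 percentage points lower from compound 1 to compound 2 (beyond the scatter) and a number 46.3 percentage points lower from compound 1 to compound 3 (beyond the scatter), with the smaller a number 28 percentage points higher from compound 2 to compound 3 (beyond the scatter) between the two substituted phenyl groups. None of them, however, removes the (3-chlorophenyl)amino group altogether or brings in a non-aromatic ring, so the direction of the step is not settled by the data. A large step in this assay is nonetheless plausible in either direction, and the author leans toward a lower number, given that compound 3, at 29.9%, already lies well under compound 1.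

The estimate for compound 4 is therefore 25%, within 3% to 65%, meaning an expected a number 4.9 percentage points lower from compound 3 to compound 4 (within the scatter).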

Compound 4, a percentage reported as inhibition, at one concentration (the size of the read-out at that concentration, not a potency): 60.4%
The estimate for compound 4 lay 35.4 percentage points below the measured number, within the range that was stated.
By their numbers in this assay, from the lowest: compound 2; then compound 3; then compound 4; then compound 1.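

Compound 4 shows that this position does not need an aromatic ring on a nitrogen for a high read-out. In this assay the 4-methylpiperazin-1-yl group, a non-aromatic ring with no hydrogen-bond donor, gives a number 30.5 percentage points higher from compound 3 to compound 4 (beyond the scatter) and a number 58.5 percentage points higher from compound 2 to compound 4 (beyond the scatter) and so outperforms both the (3-chlorophenyl)amino and the (3-(trifluoromethoxy)phenyl)amino groups at the one concentration tested. The same change does not match the best anilino group, since it gives a number 15.8 percentage points lower from compound 1 to compound 4 (beyond the scatter) and leaves compound 1 highest of the four, so the order at this position runs across the two kinds of group rather than separating them. Nothing available here explains why the ring outperforms two of the anilino groups and falls short of the third.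

The compounds shown leave open which part of the 4-methylpiperazin-1-yl group carries the effect, a question that an unsubstituted piperazine, a morpholine or an open-chain dimethylamino group at the same carbon would address. They also leave open whether the single-concentration order would hold across a full range of concentrations.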